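This account rests on a few compounds, and the source may have more. Where it says the series, first, only, none or still open, it means among the compounds named here.

Compound 1 `COc1cccc(CNCCCNc2ccnc3cc(Cc4ccccc4)ccc23)c1O` was examined in a physicochemical assay for acid dissociation, where compound 1 gives 9.47. Two other compounds share its core and differ from it at the far end of the molecule. Compound 2 `CCC(CC)c1ccc2c(NCCCNCc3cccc(OC)c3O)ccnc2c1` carries pentan-3-yl in place of benzyl on an aromatic carbon, and in this assay compound 2 gives 9.47. Compound 3 `COc1cccc(CNCCCNc2ccnc3cc(Cc4ccc(F)cc4Cl)ccc23)c1O` carries 2-chloro-4-fluorophenyl in place of phenyl on a saturated chain carbon bound to an aromatic carbon, and in this assay compound 3 gives 9.47. The steps are flat: no change at the digits printed from compound 1 to compound 2 (within the scatter), no change at the digits printed from compound 1 to compound 3 (within the scatter) and no change at the digits printed from compound 2 to compound 3 (within the scatter). Compound 1 therefore stands level with compounds 2 and 3.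

Compound 4 `c1ccc(Cc2ccc3c(NCCCNCc4ccco4)ccnc3c2)cc1` differs from compound 1 elsewhere: furan-2-yl in place of 2-hydroxy-3-methoxyphenyl on a saturated chain carbon bound to an amine nitrogen. None of the three measured steps touches this part of the molecule, so they bear on the new change only by showing that the read-out in this assay was insensitive to the groups at the other end. The leaving group carries the single hydrogen-bond donor; the entering furan-2-yl carries none. The expectation is a modest downward step, a number 0.47 log units lower from compound 1 to compound 4 (beyond the scatter), with compound 4 estimated at 9 and a range from 8.3 to 9.8.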

Compound 4, acid dissociation constant: 9.47
Beside the measured number, compound 4's estimate is 0.47 log units below it; measured number inside the range.
By their numbers in this assay, from the lowest: compounds 1, 2, 3 and 4 (each within the scatter of the next).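

Going by these compounds alone, putting furan-2-yl in place of 2-hydroxy-3-methoxyphenyl on a saturated chain carbon bound to an amine nitrogen brought no change at the digits printed from compound 1 to compound 4 (within the scatter) in this assay, so the read-out also held still at a place that none of the earlier steps had touched. The change was not a small one by count: 9 heavy atoms left and 5 entered, a six-membered ring of carbon gave way to a five-membered ring with 1 hetero atom, and the hydrogen-bond donors went from 1 to 0, yet none of this showed in the number for this pair. Nothing available explains why the step is flat.

The step replaces the ring, the hydroxy group and the methoxy group all at once, so the compounds shown cannot say how each of these would act alone, for instance in a plain phenyl at this place. Also open, as far as these compounds go, is whether a carboxylic acid or a primary amine on this chain carbon, or a longer chain in place of the (furan-2-yl)methyl group, would move the number in this assay at all.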